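Moving the ring nitrogen in the ester side chain of compound 3

The compounds below may be only part of what the source reports. "The series", "measured", "known", "first", "only" and "open" are said of these compounds alone.

Of the compounds shown here, three built on one shared core have been measured in a physicochemical assay for lipophilicity, measured as octanol-water partition; on this read-out lower numbers stand for lower lipophilicity and higher numbers for higher lipophilicity. Compound 1 `CC1=C(C(=O)OCc2ccccn2)C(c2ccco2)C2=C(CCCC2=O)N1` gives 1.4. Compound 2 `CC1=C(C(=O)OCc2ccccn2)C(c2cccs2)C2=C(CCCC2=O)N1` gives 1.77. Compound 3 `CC1=C(C(=O)OCc2cccnc2)C(c2cccc(O)c2)C2=C(CCCC2=O)N1` gives 1.21, the lowest of the three numbers; it sits within the scatter of compound 1 and beyond the scatter of compound 2. Among the compounds with values here, the only single-point step measured so far is a number 0.37 log units higher from compound 1 to compound 2 (beyond the scatter).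

Compound 4 `CC1=C(C(=O)OCc2ccccn2)C(c2cccc(O)c2)C2=C(CCCC2=O)N1` has the same atoms as compound 3, joined differently: pyridin-2-yl in place of pyridin-3-yl on a saturated chain carbon bound to an oxygen next to a carbonyl group. Within the data shown here, no measured step bears on this change; the step from compound 1 to compound 2 concerns a different ring at a different place, and both of those compounds already carry the pyridin-2-yl group that enters here. With the atom count and the hydrogen-bond donor and acceptor counts unchanged, the expectation in this assay is a step of no more than the usual scatter, a number 0.01 log units lower from compound 3 to compound 4 (within the scatter). Compound 4 is therefore estimated at 1.2, with a likely range from 0.85 to 1.55.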

Compound 4, partition coefficient: 1.58
Compound 4: the middle estimate sits 0.38 log units below what was measured, and the stated range ends below it.
By their numbers in this assay, from the lowest: compounds 3, 1, 4 and 2 (each within the scatter of the next, the first and the last beyond it).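

In this assay the atoms and the counts stay the same, yet pyridin-2-yl in place of pyridin-3-yl gives a number 0.37 log units higher from compound 3 to compound 4 (beyond the scatter) and so shows that the way the ester side chain is joined matters, not just what it contains. With pyridin-2-yl held fixed, 3-hydroxyphenyl in place of thiophen-2-yl gives a number 0.19 log units lower from compound 2 to compound 4 (within the scatter) and in place of furan-2-yl gives a number 0.18 log units higher from compound 1 to compound 4 (within the scatter) and neither step can be told apart from the scatter. On that saturated ring carbon, then, compound 4 cannot be separated from either compound 1 or compound 2, even though those two differ beyond the scatter.

The shown compounds leave open whether this step holds with furan-2-yl or thiophen-2-yl on the ring carbon, and what a plain phenyl ring or a longer chain would do in place of (pyridin-2-yl)methyl. Nothing available explains why joining the pyridine ring differently moves the number.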